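The compounds below may be only part of what the source reports. "The series", "measured", "known", "first", "only" and "open" are said of these compounds alone.

Measured compounds:
Compound 1 `O=C(Nc1ccc(Cl)c(-c2nnc3c(Cl)cccn23)c1)c1ccc(F)cc1Cl` gives > 100000 nM in a functional assay on AN3-CA cells (Homo sapiens) for antiproliferative activity, read by MTT assay, with a stated time of 72 h (a higher number here means a weaker inhibitor, a lower number a stronger inhibitor), a limit rather than a number.
Compound 2 `CS(=O)(=O)c1ccc(C(=O)Nc2ccc(Cl)c(-c3nnc4c(Cl)cccn34)c2)cc1` gives > 100000 nM in this assay, again a limit.

Compound 2 thus stands at the limit of > 100000 nM in this assay, at which 2 of the 2 values shown sit. The step that the two limits leave unreadable from compound 1 to compound 2 cannot be read. Compound 3 `Cc1cc(Cl)ccc1C(=O)Nc1ccc(Cl)c(-c2nnc3c(Cl)cccn23)c1` carries 4-chloro-2-methylphenyl in place of 4-(methylsulfonyl)phenyl on a carbonyl carbon. For the measured compounds named here, since the only related step is unreadable and both measured values are limits, no direction can be drawn. Compound 3 is therefore expected to remain near the limit, with a step of a number no higher from compound 2 to compound 3 (the limit leaves the size open) carrying little weight; the estimate for compound 3 is 100000 nM with a range of 30000 nM to 300000 nM.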

Compound 3, half-maximal inhibitory concentration: > 100000 nM
Compound 3 gave a limit, no number (the forecaster's own chance of this, stated with the estimate: 80%); the middle value lies on the limit itself.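

For the compounds shown here, compound 3 also gives only a limit, so no step among compound 1, compound 2 and compound 3 can be read: the limit of > 100000 nM in this assay, at which 3 of the 3 values shown sit. In this assay the compounds shown leave open which group on a carbonyl carbon, if any, gives a measurable value.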